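The source may hold more compounds than are shown below. What is called first, only, known or untested is meant among the compounds shown, and "the series" means these compounds.

In an assay on isolated protein (strain Sprague-Dawley) for inhibition of Amine oxidase [flavin-containing] A (Rattus norvegicus), read by spectrophotometry, with a stated time of 5 min, tested at 10 uM (a lower number here means less inhibition, a higher number more inhibition at the concentration tested (going by the name of the read-out)), compound 1 `COc1cc(=O)oc2cc(OCc3cccc(Br)c3)ccc12` gives 27% and compound 3 `O=c1cc(CO)c2ccc(OCc3cccc(Br)c3)cc2o1` gives 49%, while compound 2 `CNC(=O)COc1cc(=O)oc2cc(OCc3cccc(Cl)c3)ccc12` gives 11%, the lowest of the three, with compound 1 nearest and compound 3 furthest. Compound 4 `O=Cc1cc(=O)oc2cc(OCc3cccc(Cl)c3)ccc12` differs from compound 2 by formyl in place of (methylcarbamoyl)methoxy on an aromatic carbon. For the measured compounds named here, only one measured step bears on this change, a number 22 percentage points higher from compound 1 to compound 3 (beyond the scatter), which likewise exchanges one group for another on an aromatic carbon of the shared core; it was modest but beyond the scatter. A rise of similar size in this assay is therefore expected for compound 4, estimated as a number 19 percentage points higher from compound 2 to compound 4 (beyond the scatter), though the two changes are not the same exchange. Compound 4 is expected to give 30%, in a range from 10% to 55%.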

Compound 4, a percentage reported as inhibition, at one concentration (the size of the read-out at that concentration, not a potency): 14%
Beside the measured number, compound 4's estimate is 16 percentage points above it; the measured number falls inside the stated range.
By their numbers in this assay, from the lowest: compounds 2 and 4 (each within the scatter of the next); then compound 1; then compound 3.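

In this assay, formyl in place of (methylcarbamoyl)methoxy gives a number 3 percentage points higher from compound 2 to compound 4 (within the scatter) and so, on the aromatic carbon opposite the ring oxygen, the read-out does not tell these two groups apart, although only the chain carries a hydrogen-bond donor. The exchange of hydroxymethyl for methoxy gave a number 22 percentage points higher from compound 1 to compound 3 (beyond the scatter) on the bromine-bearing compounds, and that rise does not appear in this chlorine-bearing pair. No measurement shown explains this difference between the two exchanges. On these data alone, whether hydroxymethyl would behave the same way with chlorine on the benzyl ring stays open, as does the effect of an amine or a carboxylic acid at this position.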